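Removing the Trifluoromethyl Group from Compound 3

The source may hold more compounds than are shown below. What is called first, only, known or untested is meant among the compounds shown, and "the series" means these compounds.

The series shares one core, seen in compound 1, `CC(C)[C@H](NC(=O)c1cc(Cl)ccc1O)C(=O)Nc1cccc(Cl)c1`. In a functional assay on K562 cells (Homo sapiens) for cytotoxicity, with a stated time of 72 h (a higher number here means a weaker inhibitor, a lower number a stronger inhibitor), compound 1 gives > 10000 nM, which is a limit of the assay rather than a number. Compound 2, `COc1ccc(NC(=O)[C@@H](NC(=O)c2cc(Cl)ccc2O)C(C)C)cc1`, carries a 4-methoxyphenyl in place of the 3-chlorophenyl on an amide-type nitrogen. In this assay compound 2 gives > 10000 nM, again a limit. The step that the two limits leave unreadable from compound 1 to compound 2 therefore cannot be read. Within the data shown here, compound 3, `CC(C)[C@H](NC(=O)c1cc(Cl)ccc1O)C(=O)Nc1ccc(C(F)(F)F)cc1`, is the only one with a measured number: in this assay compound 3 gives 4500 nM. The step of an at least 2.2-fold lower number from compound 2 to compound 3 (0.34 log units; beyond the scatter) shows that a trifluoromethyl in place of methoxy on an aromatic carbon brings the number down out of the limit. Compound 4, `CC(C)[C@H](NC(=O)c1cc(Cl)ccc1O)C(=O)Nc1ccccc1`, differs from compound 3 by hydrogen in place of trifluoromethyl on an aromatic carbon. Among the measured compounds shown here, the only step that bears on this position, an at least 2.2-fold lower number from compound 2 to compound 3 (0.34 log units; beyond the scatter), points to the trifluoromethyl as what separates compound 3 from the limit of > 10000 nM in this assay, at which 2 of the 3 values shown sit. Removing it is expected to raise the number again in this assay, most likely back toward that limit. Compound 4 is therefore estimated at 12000 nM, between 5000 nM and 30000 nM. The step of a 2.7-fold higher number from compound 3 to compound 4 (0.43 log units; beyond the scatter) that this implies is an expectation, not a measurement.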

Compound 4, half-maximal inhibitory concentration: > 10000 nM
Compound 4 ended at the assay's limit (the forecaster's own chance of this, stated with the estimate: 60%); the middle value lies beyond the limit too.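

In this assay, among these compounds, the step of an at least 2.2-fold higher number from compound 3 to compound 4 (0.34 log units; beyond the scatter) tests the trifluoromethyl group directly, with hydrogen as the only change, whereas the earlier comparison set it only against methoxy. Within this pair, the measurable number of compound 3 depends on the trifluoromethyl group, and a bare aromatic carbon at this position does not keep that number. Compound 4 therefore returns to the same limit as compound 1 and compound 2: the limit of > 10000 nM in this assay, at which 3 of the 4 values shown sit.

The steps linking compound 4 to compound 1 and compound 2 join two limits and cannot be read, so any order among these three stays hidden. The compounds shown leave open whether another group at this position, such as an amine, a carboxylic acid or a longer chain, would give a measurable number like that of compound 3.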